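Rearranging the same atoms at one position of a shared core

The compounds below may be only part of what the source reports. "The series", "measured", "known", "first", "only" and "open" are said of these compounds alone.

Compound 3 `Nc1ncc(-c2cnn(C3CCNCC3)c2)cc1-c1nc2ccc(OCc3ccccc3)cc2o1` gives the highest number among the three measured compounds in an assay on isolated protein for inhibition of G protein-coupled receptor kinase 5 (Homo sapiens), read by TR-FRET, with stated times of 10 min and 1 h; a lower number here means a stronger inhibitor, a higher number a weaker inhibitor: compound 3 gives 6900 nM. Compound 1 `CN(c1ccccc1)c1ccc2oc(-c3cc(-c4cnn(C5CCNCC5)c4)cnc3N)nc2c1` gives 5050 nM, which lies within the scatter of compound 3, while compound 2 `CN(C)c1ccc2oc(-c3cc(-c4cnn(C5CCNCC5)c4)cnc3N)nc2c1` gives 1760 nM, beyond the scatter and lower than compound 3. Among the measured compounds shown here, the one measured step, a 2.9-fold lower number from compound 1 to compound 2 (0.46 log units; beyond the scatter), concerns another position. Compound 4 `COc1ccc(-c2ccc3nc(-c4cc(-c5cnn(C6CCNCC6)c5)cnc4N)oc3c2)cc1` differs from compound 3 by 4-methoxyphenyl in place of benzyloxy on an aromatic carbon. For the measured compounds named here, no measured step bears on this change, and the only step in hand is a modest one elsewhere, so in this assay a step of no more than modest size is expected, in either direction. Compound 4 is therefore estimated at 5000 nM, between 1500 nM and 16000 nM, meaning a 1.4-fold lower number from compound 3 to compound 4 (0.14 log units; within the scatter).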

Compound 4, half-maximal inhibitory concentration: 3220 nM
Estimate against measurement, compound 4: 1.6-fold (0.19 log units) above; the measured number falls inside the stated range.
By their numbers in this assay, from the lowest: compounds 2, 4, 1 and 3 (each within the scatter of the next, the first and the last beyond it).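

In this assay, 4-methoxyphenyl in place of benzyloxy gives a 2.1-fold lower number from compound 3 to compound 4 (0.33 log units; beyond the scatter), a modest step. The two groups have the same count of heavy atoms, the same aromatic ring and the same count of acceptors, which shows that at this position the way the atoms are joined is enough to move the number. Nothing measured here explains the step. Still open, going by these compounds, is how a plain phenyl or a phenoxy group on this aromatic carbon would read in this assay, and with it which part of the change carries the step.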